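Changing the carbonyl side group of compound 1

The compounds below may be only part of what the source reports. "The series", "measured", "known", "first", "only" and "open" are said of these compounds alone.

Values in a functional assay on U-937 cells (Homo sapiens) (a higher number here means a weaker inhibitor, a lower number a stronger inhibitor), for the three measured compounds:
- compound 1 `COc1cc(C(=O)NS(=O)(=O)c2ccccc2C)ccc1Cc1cn(C(=O)N(C)C)c2ccc(NC(=O)OC3CCCC3)cc12` gives 1 nM
- compound 2 `COc1cc(C(=O)NS(=O)(=O)c2ccccc2C)ccc1Cc1cn(C(=O)NCCCc2ccccc2)c2ccc(NC(=O)OC3CCCC3)cc12` gives 0.1 nM
- compound 3 `COc1cc(C(=O)NS(=O)(=O)c2ccccc2C)ccc1Cc1cn(C(=O)N(c2ccccc2)c2ccccc2)c2ccc(NC(=O)OC3CCCC3)cc12` gives 0.4 nM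

Compound 1 has the highest number of these three. Compound 4 `COc1cc(C(=O)NS(=O)(=O)c2ccccc2C)ccc1Cc1cn(C(=O)NCCN(C)C)c2ccc(NC(=O)OC3CCCC3)cc12` has not yet been measured. It carries (2-(dimethylamino)ethyl)amino in place of dimethylamino on a carbonyl carbon. The closest guide is a 10-fold lower number from compound 1 to compound 2 (1.00 log units; beyond the scatter) (with (3-phenylpropyl)amino entering at that carbon). Compound 3, also changed there, likewise sits lower than compound 1. Neither group matches the new one, so in this assay a smaller step in the same direction is expected. The estimated change is a 2.5-fold lower number from compound 1 to compound 4 (0.40 log units; beyond the scatter) in this expectation. For compound 4 the expected value is 0.4 nM within a range of 0.1 nM to 2 nM as an estimate.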

Compound 4, half-maximal inhibitory concentration: 0.1 nM
Estimate against measurement, compound 4: 4.0-fold (0.60 log units) above; measured number inside the range.
By their numbers in this assay, from the lowest: compounds 2 and 4 (each within the scatter of the next); then compound 3; then compound 1.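

In this assay, replacing dimethylamino with (2-(dimethylamino)ethyl)amino on the carbonyl carbon gives a 10-fold lower number from compound 1 to compound 4 (1.00 log units; beyond the scatter) and thus shows that this position does not need a ring in the new group to reach the low value of compound 2. Dimethylamino in place of benzyl on the chain leaves no change at the digits printed from compound 2 to compound 4 (within the scatter) as the printed result, so these two chain ends cannot be told apart here. No supporting evidence is available to explain either result.

The compounds shown leave open whether a carboxylic acid at the chain end would keep the number this low. They also leave open how a longer chain ending in dimethylamino would compare.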